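From ethyl to cyclopropyl on an amide nitrogen

The source may report more compounds than this note shows. Statements on the series, on what has been measured and on what is new or still open speak of the compounds shown alone.

In a physicochemical assay for solubility (on this read-out higher numbers stand for higher solubility and lower numbers for lower solubility), compound 1 `CCNC(=O)c1cc(C(=O)NC)nn1[C@@H](C)c1ccccc1` reads >= 137 ug/mL as a limit of the assay, not a number. Compound 2 `CNC(=O)c1cc(C(=O)N[C@H]2[C@@H]3COC[C@@H]32)c([C@@H](C)c2ccccc2)o1` also gives only a limit, at >= 131 ug/mL in this assay. Compound 3 `CNC(=O)c1cc(C(=O)NC2CC2)n([C@@H](C)c2ccccc2)n1` has cyclopropyl in place of ethyl on an amide-type nitrogen of compound 1 (cyclopropyl in place of ethyl on an amide-type nitrogen). Within the data shown here, no measured step bears on this change, so no shift beyond the scatter is expected in this assay. The estimated step of an at least 1.0-fold lower number from compound 1 to compound 3 (0.02 log units; that floor lies within the scatter) is expected to stay within that scatter. The expected value for compound 3 is 130 ug/mL with an estimated range from 65 ug/mL to 190 ug/mL in this assay.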

Compound 3, solubility: >= 165 ug/mL
Compound 3 ended at the assay's limit; the forecaster's own chance of this, stated with the estimate: 60%; at least 1.2-fold (0.10 log units) between middle value and limit.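

In this assay compound 1 reads >= 137 ug/mL, a limit. Compound 3 reads >= 165 ug/mL, also a limit. No step can be read between compound 1 and compound 3. From the compounds shown here alone, whether cyclopropyl in place of ethyl on the amide-type nitrogen shifts the read-out at all stays open.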